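The source may hold more compounds than are shown below. What is called first, only, known or untested is meant among the compounds shown, and "the series" means these compounds.

Compound 1 `O=C(CO[N+](=O)[O-])Nc1ccc(C(=O)/C=C/c2ccc(Cl)cc2)cc1` gives 60% in a functional assay on the whole organism (strain albino) for inhibition, with Rattus norvegicus as the target, read by paw edema, with stated times of 30 min and 5 h, at a dose of 100 mg/kg by the oral route; a lower number here means less inhibition, a higher number more inhibition at the dose given (going by the name of the read-out).
Compound 2 `CC(=O)c1ccc(OCC(=O)Nc2ccc(C(=O)/C=C/c3ccc(Cl)cc3)cc2)cc1` gives 55% in this assay.

Of the two numbers in this assay, compound 2 holds the lower one, and its nearest neighbour is compound 1, from which it is reached by a step of a number 5 percentage points lower from compound 1 to compound 2 (within the scatter), a difference that lies within the scatter of the assay.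

Compound 3 `C/C(=N/O)c1ccc(OCC(=O)Nc2ccc(C(=O)/C=C/c3ccc(Cl)cc3)cc2)cc1` is reached from compound 2 by one change: a group of 4 heavy atoms (2 carbon, 1 nitrogen, 1 oxygen; no ring) in place of a group of 3 heavy atoms (2 carbon, 1 oxygen; no ring), on an aromatic carbon

Going by the values given here, no measured step touches this change. Among the compounds with values here, the only step on record, a number 5 percentage points lower from compound 1 to compound 2 (within the scatter), concerns a different part of the molecule and was itself within the scatter, so there is nothing to suggest that a change at this end of the molecule moves the inhibition of paw edema in either direction. Compound 3 is therefore expected to show no step beyond the scatter, no change at the digits printed from compound 2 to compound 3 (within the scatter), and its estimated value in this assay is 55%, with a range from 40% to 70%.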

Compound 3, a percentage reported as inhibition, in the whole organism at one dose (the size of the read-out at that dose, not a potency): 49%
The estimate for compound 3 lay 6 percentage points above the measured number, and the stated range covers the measured number.
By their numbers in this assay, from the lowest: compounds 3, 2 and 1 (each within the scatter of the next, the first and the last beyond it).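

In this assay, going by these compounds alone, the first change at this end of the molecule, the acetyl giving way to a group of 4 heavy atoms with 1 hydrogen-bond donor on an aromatic carbon para to a large group, gives a number 6 percentage points lower from compound 2 to compound 3 (within the scatter), so this exchange cannot be told apart from the scatter. Within the data shown here, the larger replacement on the oxygen on a saturated carbon, with the whole group of 10 heavy atoms in place of nitro, gives a number 11 percentage points lower from compound 1 to compound 3 (beyond the scatter), the first step on record to pass beyond the scatter, though only modestly. Nothing measured here accounts for either step.

From the compounds shown here alone, whether this aromatic carbon would accept an amine or a carboxylic acid as readily remains open. So does whether a longer chain on the oxygen on a saturated carbon would widen or close the gap to the nitro end.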